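A few compounds are considered here, and "the series" means these few. Any claim that something is new, unique, unknown or untested is made for them only; others in the source may bear on it.

Measured in a functional assay on cells (Homo sapiens) for inhibition, read by MTT assay, with a stated time of 72 h; on this read-out higher numbers stand for weaker inhibition and lower numbers for stronger inhibition:
Compound 1 `CCOC(=O)Cn1ncc2c(Nc3ccc(NS(=O)(=O)c4ccc([N+](=O)[O-])cc4)cc3)ncnc21`: > 64 ug/mL (a limit)
Compound 2 `CCOC(=O)Cn1ncc2c(Nc3ccc(NS(=O)(=O)c4ccccc4)cc3)ncnc21`: > 100 ug/mL (a limit)

Compound 2 stands on a limit, > 100 ug/mL, and not on a number. Going by the values given here, the only other value shown is also a limit, as the limit of > 64 ug/mL in this assay, at which 1 of the 2 values shown sits, records, while the limit of > 100 ug/mL in this assay, at which 1 of the 2 values shown sits, records that of compound 2.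

Compound 3 `CCOC(=O)Cn1ncc2c(Nc3ccc(NC(C)=O)cc3)ncnc21` keeps the shared core and changes one group: acetyl in place of phenylsulfonyl on a nitrogen on an aromatic ring. In words, this is acetyl in place of phenylsulfonyl on a nitrogen on an aromatic ring.

Among the compounds with values here, the one measured step that bears on this is a step that the two limits leave unreadable from compound 1 to compound 2, and it gives no size to carry over. No step beyond the scatter is therefore expected, and the estimated step is a number no higher from compound 2 to compound 3 (the limit leaves the size open). This expectation is weakly grounded, and a further limit is likely. For compound 3 the expected value is 100 ug/mL, with an estimated range of 30 ug/mL to 300 ug/mL.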

Compound 3, half-maximal inhibitory concentration: > 64 ug/mL
Compound 3 ended at the assay's limit; the forecaster's own chance of this, stated with the estimate: 65%; the middle value is on the limit's open side.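

Compound 2 and compound 3 both stand on limits, so the step between them cannot be read. The compounds shown leave open at what concentration any of them reaches half-maximal inhibition, and whether phenylsulfonyl or acetyl on that nitrogen makes any difference.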